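Ether-side aryl variation in the series

A few compounds are considered here, and "the series" means these few. Any claim that something is new, unique, unknown or untested is made for them only; others in the source may bear on it.

The shared core carries a substituted phenyl on a saturated chain carbon bound to an oxygen on an aromatic ring, and it is at this ring that the compounds differ. In a functional assay on Huh-7 cells (Homo sapiens) for antiproliferative activity, read by sulforhodamine B assay, with a stated time of 72 h (on this read-out lower numbers stand for stronger inhibition and higher numbers for weaker inhibition), compound 1 `Cc1ccccc1COc1ccc(-c2cc(CN3CCN(Cc4ccc(C(F)(F)F)cc4)CC3)no2)cc1` gives 1200 nM. Compound 2 `Cc1cc(C)cc(COc2ccc(-c3cc(CN4CCN(Cc5ccc(C(F)(F)F)cc5)CC4)no3)cc2)c1` gives 600 nM in this assay. Within the data shown here, the only measured step is a 2.0-fold lower number from compound 1 to compound 2 (0.30 log units; within the scatter). Compound 2 thus holds the lower of the two numbers, but its gap to compound 1 sits inside the scatter, so no order between the two can be claimed.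

Compound 3 `Fc1ccccc1COc1ccc(-c2cc(CN3CCN(Cc4ccc(C(F)(F)F)cc4)CC3)no2)cc1` is not yet measured. It differs from compound 2 by 2-fluorophenyl in place of 3,5-dimethylphenyl on a saturated chain carbon bound to an oxygen on an aromatic ring. Among the measured compounds shown here, one step bears on this site, a 2.0-fold lower number from compound 1 to compound 2 (0.30 log units; within the scatter), and it did not exceed the scatter; the change in compound 3 returns to a singly substituted ring as in compound 1, with a fluorine in place of the methyl of compound 1. A step of a 1.8-fold higher number from compound 2 to compound 3 (0.26 log units; within the scatter) is therefore expected, of a size that stays within the scatter. Compound 3 is estimated at 1100 nM in this assay, with a range from 450 nM to 2800 nM.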

Compound 3, half-maximal inhibitory concentration: 1500 nM
Estimate against measurement, compound 3: 1.4-fold (0.13 log units) below; the range from low to high includes it.
By their numbers in this assay, from the lowest: compounds 2, 1 and 3 (each within the scatter of the next, the first and the last beyond it).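

At this position the ring now gives a first step past the scatter in this assay: 2-fluorophenyl in place of 3,5-dimethylphenyl on a saturated chain carbon bound to an oxygen on an aromatic ring gives a 2.5-fold higher number from compound 2 to compound 3 (0.40 log units; beyond the scatter) and so the choice of ring here can register in this read-out. Fluoro in place of methyl on an aromatic carbon gives a 1.3-fold higher number from compound 1 to compound 3 (0.10 log units; within the scatter) and leaves compound 1 and compound 3 without an order, while compound 2 separates from compound 3 but not from compound 1, so the 3,5-dimethylphenyl ring stands apart from only one of the two singly substituted rings. No measured evidence on the origin of these numbers is at hand.

The change from 3,5-dimethylphenyl to 2-fluorophenyl alters both the kind and the number of ring substituents in one step, and the compounds shown do not tell which of the two goes with the step. Also open, as far as these compounds go, is how the series responds to a ring carrying an amine or a carboxylic acid, or to a longer chain between this ring and the oxygen.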